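Cyclopentyl to pentyl: the group beside the ring oxygen

This account rests on a few compounds, and the source may have more. Where it says the series, first, only, none or still open, it means among the compounds named here.

Values from a functional assay on KBVIN cells (Homo sapiens) for cytotoxicity, read by MTT assay, with a stated time of 72 h; on this read-out higher numbers stand for an effect only at larger amounts of compound and lower numbers for an effect already at smaller amounts:

compound 1 `COc1ccc(Nc2cc(-c3ccccc3)oc(=O)c2)cc1`: 0.098 uM
compound 2 `COc1ccc(Nc2cc(C)oc(=O)c2)cc1`: > 30 uM, a limit of the assay
compound 3 `COc1ccc(Nc2cc(C3CCCC3)oc(=O)c2)cc1`: 4.98 uM

Compound 3 holds the highest of the two numbers shown. Its nearest neighbour is compound 1, separated by a 51-fold higher number from compound 1 to compound 3 (1.71 log units; beyond the scatter). The value of compound 2 is a limit only (the limit of > 30 uM in this assay, at which 1 of the 3 values shown sits).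

Compound 4 `CCCCCc1cc(Nc2ccc(OC)cc2)cc(=O)o1` differs from compound 3 in one place: pentyl in place of cyclopentyl on an aromatic carbon.

Within the data shown here, two measured steps bear on this position. The step of a 51-fold higher number from compound 1 to compound 3 (1.71 log units; beyond the scatter) and the step of an at least 6.0-fold lower number from compound 2 to compound 3 (0.77 log units; beyond the scatter) together show that the group on this aromatic carbon moves the read-out strongly, with phenyl far ahead of cyclopentyl and cyclopentyl ahead of methyl. Pentyl keeps the count of cyclopentyl but loses the ring; among the measured groups the one without a ring, methyl, sits at the limit, so some loss against compound 3 is plausible, though nothing measured separates ring from chain at equal size. A modest step to a higher number, or none beyond the scatter, is therefore expected in this assay.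

Compound 4 is expected to give 9 uM, between 2.5 uM and 30 uM. This estimate means a 1.8-fold higher number from compound 3 to compound 4 (0.26 log units; within the scatter).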

Compound 4, concentration for half-maximal effect: 4.84 uM
For compound 4 the middle estimate is 1.9-fold (0.27 log units) above the measured one; the measured number falls inside the stated range.
By their numbers in this assay, from the lowest: compound 1; then compounds 4 and 3 (each within the scatter of the next). At a limit, above all of these: compound 2.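

In this assay, opening the ring of cyclopentyl to pentyl gives a 1.0-fold lower number from compound 3 to compound 4 (0.01 log units; within the scatter), so the ring itself is not required to hold the level of compound 3, and ring and chain do not separate at this position. A group without a ring can therefore stand well clear of methyl, as the step of an at least 6.1-fold lower number from compound 2 to compound 4 (0.79 log units; beyond the scatter) shows, although that step starts from a limit of compound 2 and gives only a minimum size: the limit of > 30 uM in this assay, at which 1 of the 4 values shown sits. Phenyl remains apart from the saturated groups, with a 49-fold higher number from compound 1 to compound 4 (1.69 log units; beyond the scatter), so among the compounds shown the large gain belongs to the aromatic ring and to neither cyclopentyl nor pentyl.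

Going by these compounds, whether a longer chain, a branched chain such as isopentyl, or a cyclohexyl ring would move the number beyond the level of compounds 3 and 4 remains open. Also open, on these data alone, is whether a benzyl group or a pyridyl or thienyl ring would come close to compound 1 at this position.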